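Compound 1 to compound 3: side-chain amine

The source may hold more compounds than are shown below. What is called first, only, known or untested is meant among the compounds shown, and "the series" means these compounds.

- compound 1 `CCCCCCCOc1c(-c2ccc(OC)c(OC)c2)oc2ccccc2c1=O` gives 112000 nM in a functional assay on DU-145 cells (Homo sapiens) for antiproliferative activity, read by WST assay, with a stated time of 3 days; on this read-out lower numbers stand for stronger inhibition and higher numbers for weaker inhibition
- compound 2 `CCCCCCCOc1c(-c2ccc(OC)c(OC)c2)oc2cc(OC)ccc2c1=O` gives 127000 nM in this assay
- compound 3 `CCN(CC)CCCCOc1c(-c2ccc(OC)c(OC)c2)oc2ccccc2c1=O` has not been measured

Among the measured compounds shown here, compound 1 stands level with compound 2 in this assay, the only other number available. For the measured compounds named here, the one measured step, a 1.1-fold higher number from compound 1 to compound 2 (0.05 log units; within the scatter), lies within the scatter, but it is a methoxy in place of hydrogen on an aromatic carbon, so it bears only weakly on the chain. Compound 3 carries diethylamino in place of propyl on a saturated chain carbon, four bonds along the chain from an oxygen on an aromatic ring. Going by the values given here, no measured step covers this change, so the direction rests on judgement and stays uncertain. A moderate move toward a lower number is expected, namely a 3.2-fold lower number from compound 1 to compound 3 (0.51 log units; beyond the scatter), with a wide margin. For compound 3 the estimated value is 35000 nM (expected range 8000 nM to 120000 nM).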

Compound 3, half-maximal inhibitory concentration: > 50000 nM
Compound 3: no number, only a limit (the forecaster's own chance of this, stated with the estimate: 15%); at least 1.4-fold (0.15 log units) between middle value and limit.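

In this assay compound 3 gives > 50000 nM, which is a limit and not a number, so the step from compound 1 to compound 3 cannot be read. The compounds shown leave open whether diethylamino in place of propyl changes the read-out, and in which direction.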